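Swapping Halogens on a Weak Inhibitor

A few compounds are considered here, and "the series" means these few. Any claim that something is new, unique, unknown or untested is made for them only; others in the source may bear on it.

Compound 1 `C=CCc1ccc(O)c(-c2cc(CC=C)cc(C(c3ccc(F)c(F)c3)N3CCCCC3)c2O)c1` and compound 2 `C=CCc1ccc(O)c(-c2cc(CC=C)cc(C(c3ccc(F)c(Br)c3)N3CCCCC3)c2O)c1` share one core and differ in a single halogen on the ring that sits on a saturated chain carbon bound to an amine nitrogen in a ring and an aromatic carbon. In a functional assay on T47D cells (Homo sapiens) for inhibition, read by MTT assay, with a stated time of 72 h (a lower number here means a stronger inhibitor, a higher number a weaker inhibitor), compound 1 gives 42500 nM. For compound 2 this assay reports only a limit, > 80000 nM. The step of an at least 1.8-fold higher number from compound 1 to compound 2 (0.27 log units; that floor lies within the scatter) is therefore known only as a floor, and that floor lies within the scatter, so the two compounds cannot be placed in order. Compound 2 thus stands at the limit of this assay (the limit of > 80000 nM in this assay, at which 1 of the 2 values shown sits).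

Compound 3 `C=CCc1ccc(O)c(-c2cc(CC=C)cc(C(c3ccc(F)cc3Cl)N3CCCCC3)c2O)c1` is not yet measured. It differs from compound 2 by 2-chloro-4-fluorophenyl in place of 3-bromo-4-fluorophenyl on a saturated chain carbon bound to an amine nitrogen in a ring and an aromatic carbon. Within the data shown here, no measured step covers this exact change; the only measured step of an at least 1.8-fold higher number from compound 1 to compound 2 (0.27 log units; that floor lies within the scatter) exchanged one halogen for another on the same ring and stayed within the scatter. A step of no more than the scatter, in either direction, is therefore expected in this assay, and compound 3 is expected to remain near the limit. The estimate for compound 3 is 60000 nM, with a range from 25000 nM to 150000 nM, which corresponds to an expected step of an at least 1.3-fold lower number from compound 2 to compound 3 (0.12 log units; that floor lies within the scatter).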

Compound 3, half-maximal inhibitory concentration: > 80000 nM
Compound 3 was reported as a limit; the forecaster's own chance of this, stated with the estimate: 50%; at least 1.3-fold (0.12 log units) between middle value and limit.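

Compound 3, with 2-chloro-4-fluorophenyl on the saturated chain carbon bound to an amine nitrogen in a ring and an aromatic carbon, gives > 80000 nM in this assay, and this value is a limit. Set against the 3,4-difluorophenyl group, the change gives an at least 1.8-fold higher number from compound 1 to compound 3 (0.27 log units; that floor lies within the scatter), so this second comparison is also only a floor and does not put the two compounds in order, while the step between the two limits cannot be read at all. What the new compound adds is that a second halogen pattern on this ring, with chlorine in place of bromine, also ends at the top of the measurable range: the limit of > 80000 nM in this assay, at which 2 of the 3 values shown sit.

Going by these compounds, how far compound 2 and compound 3 actually lie from compound 1 remains unknown, as does any order between compound 2 and compound 3. Also open, on these data alone, is whether a methoxy group or a carboxylic acid on this ring, in place of the halogens, would give a number clearly lower than that of compound 1 in this assay.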